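The source may hold more compounds than are shown below. What is called first, only, known or untested is meant among the compounds shown, and "the series" means these compounds.

Measured so far in a functional assay on HCT-116 cells (Homo sapiens) for cytotoxicity, read by MTT assay, with a stated time of 72 h; on this read-out lower numbers stand for stronger inhibition and higher numbers for weaker inhibition:

Compound 1 `CN1CCN(CCCCCn2c3c(c4ccccc42)C(=O)c2c[n+]([O-])c4ccccc4c2C3=O)CC1` gives 1220 nM.
Compound 2 `O=C1c2c[n+]([O-])c3ccccc3c2C(=O)c2c1c1ccccc1n2Cc1cn([C@H]2C[C@H](O)[C@@H](CO)O2)nn1` gives 120 nM.
Compound 3 `O=C1c2c[n+]([O-])c3ccccc3c2C(=O)c2c1c1ccccc1n2Cc1cn([C@H]2O[C@H](CO)[C@@H](O)[C@H]2O)nn1` gives 710 nM.

Among these three numbers compound 1 stands highest. Its nearest neighbour is compound 3, whose number lies within the usual scatter of compound 1, so no order can be read between the two. Compound 2 lies furthest away, with a number well beyond the scatter below that of compound 1.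

Within the data shown here, the only step between measured compounds that differ in one place is a 5.9-fold higher number from compound 2 to compound 3 (0.77 log units; beyond the scatter), a change of the sugar on the aromatic nitrogen of the triazole. It tells nothing about the chain-and-piperazine side of the shared core.

Compound 4 `O=C1c2c[n+]([O-])c3ccccc3c2C(=O)c2c1c1ccccc1n2CCCCN1CCNCC1` differs from compound 1 as follows: piperazin-1-yl in place of (4-methylpiperazin-1-yl)methyl on a saturated chain carbon, four bonds along the chain from an aromatic nitrogen. Cut one bond further out, the same difference reads 4-(4-methylpiperazin-1-yl)butyl to 3-(piperazin-1-yl)propyl. Among the measured compounds shown here, no measured step covers this part of the molecule, so no direction can be drawn from the data, and a step within the scatter is the plain expectation, with wide uncertainty.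

Compound 4 is therefore expected at 1000 nM, with a range from 350 nM to 3000 nM. This estimate amounts to an expected step of a 1.2-fold lower number from compound 1 to compound 4 (0.09 log units; within the scatter).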

Compound 4, half-maximal inhibitory concentration: 700 nM
For compound 4 the middle estimate is 1.4-fold (0.15 log units) above the measured one, and the stated range covers the measured number.
By their numbers in this assay, from the lowest: compound 2; then compounds 4, 3 and 1 (each within the scatter of the next).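

In this assay, the chain-and-piperazine side of the core now has its first measured step: piperazin-1-yl in place of (4-methylpiperazin-1-yl)methyl gives a 1.7-fold lower number from compound 1 to compound 4 (0.24 log units; within the scatter), so this change leaves no readable difference in the number. The step shortens the chain, removes the methyl group from the piperazine ring and adds a hydrogen-bond donor all at once, so a small combined result does not show that each of these changes alone is without effect, since separate effects could offset one another. No measurement shown here bears on why the number stays within the scatter.

Going by these compounds, what remains open is how the chain and the ring methyl each count alone, which a compound carrying a plain piperazin-1-yl group on the same chain as in compound 1, or a 4-methylpiperazin-1-yl group on the chain of compound 4, could separate. Also open, on these data alone, is whether a morpholine ring or a dimethylamino group in place of the piperazine, or a longer chain such as an octyl chain, would shift the number beyond the scatter.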